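A few compounds are considered here, and "the series" means these few. Any claim that something is new, unique, unknown or untested is made for them only; others in the source may bear on it.

Compound 2 `COc1ccc(C(=O)/C=C/c2cc(-c3cc(OC)c(OC)c(OC)c3)n[nH]2)cc1` and compound 1 `COc1cc(-c2cc(/C=C/C(=O)c3ccc(N)cc3)[nH]n2)cc(OC)c1OC` share one core and differ only in one ring substituent. In a functional assay on CCRF-CEM cells (Homo sapiens) for cytotoxicity, read by sulforhodamine B assay, with a stated time of 48 h, tested at 0.01 uM (a higher number here means a weaker effect of the compound at the concentration tested, a lower number a stronger effect), compound 1 gives 96% and compound 2 gives 99%, the shift being a number 3 percentage points higher from compound 1 to compound 2 (within the scatter). Compound 2 therefore holds the higher of the two numbers, yet the gap to compound 1 falls within the scatter. Compound 3 `COc1cc(-c2cc(/C=C/C(=O)c3ccc(F)c(F)c3)[nH]n2)cc(OC)c1OC` carries 3,4-difluorophenyl in place of 4-methoxyphenyl on a carbonyl carbon. Within the data shown here, no measured step covers this exact change; the only step at hand, on the same ring, stayed within the scatter. A step of about a number 3 percentage points lower from compound 2 to compound 3 (within the scatter) is expected, with compound 3 estimated at 96% ranging from 84% to 106%.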

Compound 3, a percentage reported as activity, at one concentration (the size of the read-out at that concentration, not a potency): 99%
For compound 3 the middle estimate is 3 percentage points below the measured one, and the stated range covers the measured number.
By their numbers in this assay, from the lowest: compounds 1, 2 and 3 (each within the scatter of the next).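

In this assay, putting 3,4-difluorophenyl in place of 4-methoxyphenyl on a carbonyl carbon gives no change at the digits printed from compound 2 to compound 3 (within the scatter) and putting it in place of 4-aminophenyl gives a number 3 percentage points higher from compound 1 to compound 3 (within the scatter), so a ring with two fluorines and no hydrogen-bond acceptor cannot be told apart from the two earlier rings at this concentration. No measured data explain this result. Still open, going by these compounds, is whether a different group on the carbonyl carbon, such as a carboxylic acid or a longer chain, would separate from these three, and how all of them compare at higher concentrations.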